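Sulfone series: chloro for methyl, activity expected

A few compounds are considered here, and "the series" means these few. Any claim that something is new, unique, unknown or untested is made for them only; others in the source may bear on it.

Measured compounds:
- compound 1, `O=S(=O)(CC1=NCCO1)C1=NNCC1c1ccccc1`: in a functional assay, read by Griess assay, with a stated time of 150 min, tested at 50 ug/mL (a higher number here means a stronger effect of the compound at the concentration tested, a lower number a weaker effect), compound 1 gives "not active" (no number reported)
- compound 2, `O=S(=O)(CC1=NCCS1)c1c(-c2ccc(Cl)cc2)nn(-c2ccccc2)c1-c1ccc(Cl)cc1`: in this assay compound 2 gives "not active" (no number reported)
- compound 3, `Cc1ccc(C2CNN=C2S(=O)(=O)CC2=NCCO2)cc1`: in this assay compound 3 gives 45.9%

Among the measured compounds shown here, compound 3 stands alone with the only numerical read-out in this assay; the two other entries carry no number, so no ordering among the three can be drawn from figures, and no pair of measured compounds differs in a single place.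

Compound 4, `O=S(=O)(CC1=NCCO1)C1=NNCC1c1ccc(Cl)cc1`, is the next entry and has not yet been measured. It differs from compound 3 by chloro in place of methyl on an aromatic carbon.

For the measured compounds named here, compound 1, which carries the unsubstituted ring at the same position, is reported as not active, while compound 3 with the methyl gives a clear number; the chloro analogue has no direct precedent here. A step downward from compound 3, of moderate size and possibly no larger than the scatter, is expected, a number 10.9 percentage points lower from compound 3 to compound 4 (beyond the scatter). For compound 4 the estimated read-out is 35%, with a range from 5% to 60%.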

Compound 4, a percentage reported as activity, at one concentration (the size of the read-out at that concentration, not a potency): "not active" (no number reported)
For compound 4 the study gives words and no number; no gap can be computed for the estimate.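

In this assay, among the compounds shown here, compound 3 gives 45.9% and compound 4 gives "not active" (no number reported) and no step between the two can be read. The compounds shown leave open how far the read-out of compound 4 lies from that of compound 3. No measured evidence bears on this result.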